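Ethylamino in place of methylamino on a shared core

The source may hold more compounds than are shown below. What is called first, only, known or untested is meant among the compounds shown, and "the series" means these compounds.

Measured compounds in this study:
compound 1 `CCNc1nc(NCc2ccc(NC(=O)c3ccc(F)cc3)cc2)c2ccccc2n1` — 1400 nM
compound 2 `CNc1nc(NCc2ccc(NC(=O)c3ccc(F)cc3)cc2Cl)c2ccccc2n1` — 2000 nM
compound 3 `CNc1nc(NCc2ccc(C(=O)Nc3ccc(F)cc3)cc2)c2ccccc2n1` — 2900 nM

All three were examined in a functional assay on HCT-116 cells (Homo sapiens) for inhibition, read by luminescence and resazurin assay, with a stated time of 3 days; on this read-out lower numbers stand for stronger inhibition and higher numbers for weaker inhibition. In this assay compound 2 gives 2000 nM, the second highest of the three numbers. Its nearest neighbour is compound 1, which gives 1400 nM, a gap that stays within the scatter of repeated measurements. Its furthest neighbour is compound 3, which gives 2900 nM, again within the scatter. On the numbers shown, then, the three measured compounds cannot be separated from one another.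

The next compound, compound 4 `CCNc1nc(NCc2ccc(NC(=O)c3ccc(F)cc3)cc2Cl)c2ccccc2n1`, differs from compound 2 in one place: methyl in place of hydrogen on a saturated chain carbon bound to a nitrogen on an aromatic ring. Cut one bond further out, the same difference reads methyl to ethyl, or methylamino to ethylamino. Going by the values given here, no pair of measured compounds isolates this change. Compound 1 does carry the ethylamino group, but it also lacks the chlorine that compound 2 and compound 4 both bear, so nothing in the measured set tells how the ethyl alone behaves.

Among the compounds with values here, with one carbon entering an alkylamino chain and no measured step to lean on, the step expected in this assay from compound 2 to compound 4 is a 1.3-fold lower number from compound 2 to compound 4 (0.10 log units; within the scatter), nothing beyond the scatter in either direction. For compound 4 the estimate is 1600 nM, with a range from 600 nM to 4500 nM.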

Compound 4, half-maximal inhibitory concentration: 1500 nM
For compound 4 the middle estimate is 1.1-fold (0.03 log units) above the measured one; measured number inside the range.
By their numbers in this assay, from the lowest: compounds 1, 4, 2 and 3 (each within the scatter of the next, the first and the last beyond it).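

In this assay, methylamino to ethylamino, with methyl in place of hydrogen on a saturated chain carbon bound to a nitrogen on an aromatic ring, now has a reading of its own: a 1.3-fold lower number from compound 2 to compound 4 (0.12 log units; within the scatter). Going by these compounds alone, the result also isolates a second change that the earlier compounds could not separate, chloro in place of hydrogen on an aromatic carbon, which with the ethylamino group in place gives a 1.1-fold higher number from compound 1 to compound 4 (0.03 log units; within the scatter); neither the extra carbon on the chain nor the chlorine on the ring therefore moves the number beyond the scatter in these pairs. Nothing among the accompanying data accounts for either outcome, and no independent measurement bears on these two changes.

Within the data shown here, whether a longer chain such as propylamino or butylamino, or a hydroxyethylamino group, would stay as close to compound 4 remains open, since the single added carbon describes only the step from methylamino to ethylamino. Also open, going by these compounds, is whether fluoro or methoxy in place of the chloro would leave the number within the scatter, and whether the ethyl step would read the same on a compound without the chlorine.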